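This account rests on a few compounds, and the source may have more. Where it says the series, first, only, none or still open, it means among the compounds named here.

Working notes on the cytotoxicity series

Compound 1 `O=C1C[C@H](OCc2cn(C(=O)c3ccccc3)nn2)[C@H]2CO[C@@H]1O2` is the reference point of the set. In a functional assay on MDA-MB-231 cells (Homo sapiens) for cytotoxicity, read by MTT assay, with a stated time of 48 h (a lower number here means a stronger inhibitor, a higher number a weaker inhibitor), compound 1 gives 25900 nM. Compound 2 `CCCCCCCCn1cc(CO[C@H]2CC(=O)[C@@H]3OC[C@H]2O3)nn1` carries octyl in place of benzoyl on an aromatic nitrogen. In this assay compound 2 returns only a limit of the assay, > 50000 nM, and no number. The step of an at least 1.9-fold higher number from compound 1 to compound 2 (0.28 log units; that floor lies within the scatter) is therefore known only as a floor. Compound 3 `CC(=O)N(Cc1cn(C(=O)c2ccccc2)nn1)[C@H]1CC(=O)[C@@H]2OC[C@H]1O2` rests on a different core; how the core of compound 3 differs from the core of compound 1 is not broken down here. In this assay compound 3 also returns only a limit of the assay, > 50000 nM. For the measured compounds named here, compound 4 `CCCCCCCCn1cc(CN(C(C)=O)[C@H]2CC(=O)[C@@H]3OC[C@H]2O3)nn1` has not yet been measured in this assay; it bears octyl in place of benzoyl on an aromatic nitrogen, the same change as the one from compound 1 to compound 2, at a place described in the same words. The weight of the data is given by the limit of > 50000 nM in this assay, at which 2 of the 3 values shown sit. Because of an at least 1.9-fold higher number from compound 1 to compound 2 (0.28 log units; that floor lies within the scatter) the change is not expected to bring any gain in this assay. Compound 3 is already at the limit, so compound 4 is expected to sit at or beyond it; the estimated step that the limit leaves unreadable from compound 3 to compound 4 is a rough guess, with a high chance that only a limit is reported. For compound 4 the estimate in this assay is 90000 nM, with a range from 50000 nM to 250000 nM.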

Compound 4, half-maximal inhibitory concentration: > 50000 nM
Compound 4: no number, only a limit; the forecaster's own chance of this, stated with the estimate: 85%; the middle value is on the limit's open side.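

In this assay compound 4 returns > 50000 nM, which is a limit of the assay and not a number. For the compounds shown here, compound 3 also sits at a limit, so no step between compound 3 and compound 4 can be read.

The compounds shown leave open the actual values of compound 2, compound 3 and compound 4, and so whether octyl in place of benzoyl has any comparable effect on the two cores. The data stop at: the limit of > 50000 nM in this assay, at which 3 of the 4 values shown sit.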